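The source may report more compounds than this note shows. Statements on the series, on what has been measured and on what is new or still open speak of the compounds shown alone.

In a functional assay on K562 cells (Homo sapiens) for cytotoxicity, in the presence of a further agent that is not named here (a higher number here means a weaker inhibitor, a lower number a stronger inhibitor), two compounds have been measured so far. Compound 1 (`Clc1ccc(-c2cc(-c3ccc(Cl)o3)cc(-c3ccsc3)n2)cc1`) gives 18700 nM, and compound 2 (`Clc1ccc(-c2cc(-c3ccoc3)cc(-c3cccs3)n2)cc1`) gives 21100 nM. These two values lie within the usual scatter of each other, so compound 2 stands level with compound 1, and the numbers set no order between them.

The next compound to be tested is compound 3 (`Clc1ccc(-c2cc(-c3ccoc3)cc(-c3ccsc3)n2)cc1`). It has the same atoms as compound 2, joined differently, with thiophen-3-yl in place of thiophen-2-yl on an aromatic carbon. Within the data shown here, no measured pair of compounds differing in one place shows what such a change does, so any expectation here rests on little.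

Compound 1 already carries thiophen-3-yl at that place and gives 18700 nM, which offers a weak hint that this group is tolerated at a similar level. No shift beyond the scatter is therefore expected, in either direction, and the estimated change is a 1.1-fold lower number from compound 2 to compound 3 (0.02 log units; within the scatter). For compound 3, the expected value in this assay is 20000 nM, with an estimated range of 9000 nM to 40000 nM.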

Compound 3, half-maximal inhibitory concentration: 730 nM
Compound 3: middle estimate off by 27-fold (1.44 log units), on the high side, outside the stated range (below it).
By their numbers in this assay, from the lowest: compound 3; then compounds 1 and 2 (each within the scatter of the next).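

In this assay, swapping thiophen-2-yl for thiophen-3-yl gives a 29-fold lower number from compound 2 to compound 3 (1.46 log units; beyond the scatter), so at this place next to the ring nitrogen, the point at which the thiophene ring is attached matters greatly, even though the two groups have the same atoms. Thiophen-3-yl alone does not account for the low number, since compound 1 carries it too, and the step at the other place, furan-3-yl in place of 5-chlorofuran-2-yl, gives a 26-fold lower number from compound 1 to compound 3 (1.41 log units; beyond the scatter). Among these three compounds, the low number appears only where thiophen-3-yl and furan-3-yl stand together: compound 2 has only the furan-3-yl group and compound 1 only the thiophen-3-yl group.

The second step changes both the chlorine and the attachment point of the furan, so these compounds cannot separate the two, and a plain furan-2-yl group or a 5-chlorofuran-3-yl group would be needed to do so. Nothing available here explains why either change has so large an effect.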